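The source may report more compounds than this note shows. Statements on the series, on what has been measured and on what is new or still open speak of the compounds shown alone.

In an assay on isolated protein for binding affinity to 5-hydroxytryptamine receptor 1B (Rattus norvegicus) (on this read-out lower numbers stand for stronger inhibition and higher numbers for weaker inhibition), compound 1 `C1=C(CCN2CCN(c3cccc4c3OCCO4)CC2)c2ccccc2C1` gives 251 nM, the lowest of the three numbers in hand. Compound 3 `c1ccc2c(c1)CC2CCCCN1CCN(c2cccc3c2OCCO3)CC1` gives 631 nM and compound 2 `COc1cc2c(cc1OC)C(CCN1CCN(c3cccc4c3OCCO4)CC1)CC2` gives 676 nM; both of these gaps to compound 1 lie beyond the scatter. Compound 4 `Clc1cccc2c1CC2CCN1CCN(c2cccc3c2OCCO3)CC1` has not yet been measured in this assay. It differs from compound 1 by a group of 9 heavy atoms (8 carbon, 1 chlorine; one four-membered non-aromatic ring of carbon only, one six-membered aromatic ring of carbon only) in place of a group of 9 heavy atoms (9 carbon; one five-membered non-aromatic ring of carbon only, one six-membered aromatic ring of carbon only), on a saturated chain carbon, two bonds along the chain from an amine nitrogen in a ring. Within the data shown here, no measured pair shows this particular change, so its size is uncertain; a modest move toward a higher number is expected, one that may still sit within the scatter of repeated measurements. Compound 4 is therefore expected to give 400 nM, with a likely range from 150 nM to 1100 nM. This expectation amounts to a step of a 1.6-fold higher number from compound 1 to compound 4 (0.20 log units; within the scatter) in this assay.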

Compound 4, inhibition constant: 708 nM
The estimate for compound 4 lay 1.8-fold (0.25 log units) below the measured number; measured number inside the range.
By their numbers in this assay, from the lowest: compound 1; then compounds 3, 2 and 4 (each within the scatter of the next).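

In this assay, the set now holds its first comparison of compounds differing in one place, with a 2.8-fold higher number from compound 1 to compound 4 (0.45 log units; beyond the scatter) at the saturated chain carbon, two bonds along the chain from an amine nitrogen in a ring. The step is beyond the scatter, so this position does not accept the exchange of groups without a change in the number. The data in hand offer no explanation for the step.

Ring size, chlorine and the double bond all change together, so the share of each remains open. From the compounds shown here alone, how a fluorine in place of the chlorine would read in this assay also remains open.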